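A few compounds are considered here, and "the series" means these few. Any claim that something is new, unique, unknown or untested is made for them only; others in the source may bear on it.

Measured compounds:
- compound 1, `COc1cccc(CNCCCNc2ccnc3cc(C4CCCCC4)ccc23)c1O`: 1080 nM
- compound 2, `COc1ccc(F)cc1CNCCCNc1ccnc2cc(C3CCCCC3)ccc12`: 2290 nM
- compound 3, `COc1ccc(F)cc1CNCCCNc1ccnc2cc(Cc3cccc(C(F)(F)F)c3)ccc12`: 440 nM

All three were tested in an ADME assay on HepG2 cells (Homo sapiens) for cytotoxicity, read by luminescence, CellTiter-Glo and ATP content, with a stated time of 72 h; on this read-out lower numbers stand for an effect already at smaller amounts and higher numbers for an effect only at larger amounts of compound. Compound 1 holds the second highest of the three numbers. Compound 2 sits above it, by a 2.1-fold higher number from compound 1 to compound 2 (0.33 log units; beyond the scatter), and compound 3 sits below it, a gap that lies beyond the usual scatter.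

Compound 4, `COc1ccccc1Oc1ccc2c(NCCCNCc3cccc(OC)c3O)ccnc2c1`, has not yet been measured. It differs from compound 1 in one place: 2-methoxyphenoxy in place of cyclohexyl on an aromatic carbon.

Going by the values given here, one measured step touches the same aromatic carbon: going from compound 2 to compound 3, where the cyclohexyl is exchanged for a 3-(trifluoromethyl)benzyl, gave a 5.2-fold lower number from compound 2 to compound 3 (0.72 log units; beyond the scatter). The group entering compound 4 is not that group, so this step is only a loose guide, but it is the only one that speaks to a change at this position, and it points toward a lower number. A modest lowering is therefore the expectation, with the possibility that the change stays within the scatter.

Compound 4 is expected to give 700 nM, within a range of 300 nM to 1800 nM. This estimate means a 1.5-fold lower number from compound 1 to compound 4 (0.19 log units; within the scatter) is expected.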

Compound 4, half-maximal effective concentration: 11200 nM
Compound 4: middle estimate off by 16-fold (1.20 log units), on the low side; the whole stated range lies below it.
By their numbers in this assay, from the lowest: compound 3; then compound 1; then compound 2; then compound 4.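

In this assay, the aromatic carbon that carried cyclohexyl can shift the number far upward as well as downward: the exchange for 2-methoxyphenoxy gave a 10-fold higher number from compound 1 to compound 4 (1.02 log units; beyond the scatter) and is the largest step seen so far. The earlier change at this carbon, a 5.2-fold lower number from compound 2 to compound 3 (0.72 log units; beyond the scatter), ran the opposite way, so the direction depends on the entering group or on the rest of the molecule, since the two pairs carry different groups on the chain nitrogen. Nothing available explains this rise.

As far as these compounds go, it remains open whether the rise belongs to the oxygen link, the methoxy group or the added aromatic ring; plain phenoxy and 2-methoxybenzyl at this carbon would separate these. From the compounds shown here alone, whether 2-methoxyphenoxy acts alike alongside the 5-fluoro-2-methoxyphenyl group also remains open.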